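The source may report more compounds than this note shows. Statements on the series, on what has been measured and on what is new or still open speak of the compounds shown alone.

Measured in an ADME assay (liver) for metabolic stability, with Liver microsome (Rattus norvegicus) as the target, using microsomes; on this read-out lower numbers stand for slow clearance and higher numbers for fast clearance:
- compound 1 `CN(C(=O)c1cc(-c2ccccn2)[nH]n1)c1ccc(OCc2ccc3ccccc3c2)cc1`: 30 mL/min/kg
- compound 2 `CN(C(=O)c1cc(-c2ccccc2)n[nH]1)c1ccc(OCB2C=Cc3ccccc3N2)cc1`: 5.67 mL/min/kg
- compound 3 `CN(C(=O)c1csc(-c2cccnc2)n1)c1ccc(OCc2ccc3ccccc3c2)cc1`: > 283 mL/min/kg

Compound 3 gives > 283 mL/min/kg, which is a limit of this assay and not a number.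

Compound 4 `CN(C(=O)c1cc(-c2ccccc2)n[nH]1)c1ccc(OCc2ccc3ccccc3c2)cc1` has not yet been measured. It carries 3-phenyl-1H-pyrazol-5-yl in place of 2-(pyridin-3-yl)-1,3-thiazol-4-yl on a carbonyl carbon.

The closest evidence is a swap in the opposite sense. Placing 2-(pyridin-3-yl)-1,3-thiazol-4-yl where 5-(pyridin-2-yl)-1H-pyrazol-3-yl stood gave an at least 9.4-fold higher number from compound 1 to compound 3 (0.97 log units; beyond the scatter). Compound 4 returns to a similar group, although with phenyl rather than pyridin-2-yl, so a fall of at least similar size is expected in this assay, beyond the scatter. This rests on a single step, and compound 1 at 30 mL/min/kg serves as the nearest guide.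

The expected change is an at least 7.0-fold lower number from compound 3 to compound 4 (0.84 log units; beyond the scatter).

For compound 4 the estimated clearance is 40 mL/min/kg, with an expected range of 12 mL/min/kg to 130 mL/min/kg.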

Compound 4, clearance: 6.83 mL/min/kg
Compound 4: middle estimate off by 5.9-fold (0.77 log units), on the high side, and the stated range ends above it.
By their numbers in this assay, from the lowest: compounds 2 and 4 (each within the scatter of the next); then compound 1. At a limit, above all of these: compound 3.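

In this assay, 3-phenyl-1H-pyrazol-5-yl in place of 2-(pyridin-3-yl)-1,3-thiazol-4-yl on the carbonyl carbon gives an at least 41-fold lower number from compound 3 to compound 4 (1.61 log units; beyond the scatter), so the group at this place has a large bearing on the read-out. The two pyrazole groups are not interchangeable either: 3-phenyl-1H-pyrazol-5-yl in place of 5-(pyridin-2-yl)-1H-pyrazol-3-yl gives a 4.4-fold lower number from compound 1 to compound 4 (0.64 log units; beyond the scatter). At the other end of the molecule, the swap of the boron-containing group for the carbon-only one gives a 1.2-fold higher number from compound 2 to compound 4 (0.08 log units; within the scatter), which does not separate the two.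

As far as these compounds go, the full size of the first step stays open, because compound 3 gives a limit and not a number: the limit of > 283 mL/min/kg in this assay, at which 1 of the 4 values shown sits. Also open are which of the two rings exchanged in that step matters more and how a simple amine would fare on that carbonyl carbon.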